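A methyl added to a weak amide inhibitor

The source may report more compounds than this note shows. Statements on the series, on what has been measured and on what is new or still open speak of the compounds shown alone.

Measured compounds:
compound 1 `O=C(/C=C/C=C/c1ccccc1)Nc1cccc(Br)c1`: 105000 nM
compound 2 `O=C(C/C=C/c1ccccc1)Nc1ccccc1`: 297000 nM

Of the compounds shown here, two have been tested in an assay on isolated protein for inhibition of Amine oxidase [flavin-containing] A (Homo sapiens), with a stated time of 20 min; a higher number here means a weaker inhibitor, a lower number a stronger inhibitor. Compound 1 gives 105000 nM. Compound 2 gives 297000 nM, the higher of the two numbers, and the gap between compound 1 and compound 2 lies beyond the usual scatter of this assay. Within the data shown here, both are weak inhibitors, and the only comparison at hand is between two compounds that differ in more than one place, so no single step can be read from them.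

Compound 3 `Cc1cccc(NC(=O)C/C=C/c2ccccc2)c1` is the next compound, not yet measured. It differs from compound 2 in one place: methyl in place of hydrogen on an aromatic carbon. Nothing measured here speaks to the effect of such a change, so the expectation rests on the general observation that a single methyl on an aromatic ring rarely moves a number like this by much. Compound 3 is therefore expected to stay near compound 2, with a step of a 1.4-fold lower number from compound 2 to compound 3 (0.13 log units; within the scatter) that is expected to fall within the scatter. Compound 3 is estimated at 220000 nM, within a range from 80000 nM to 600000 nM.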

Compound 3, half-maximal inhibitory concentration: 74800 nM
Compound 3: middle estimate off by 2.9-fold (0.47 log units), on the high side, outside the stated range (below it).
By their numbers in this assay, from the lowest: compounds 3 and 1 (each within the scatter of the next); then compound 2.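

In this assay, among these compounds, methyl in place of hydrogen on an aromatic carbon, meta to a large group, gives a 4.0-fold lower number from compound 2 to compound 3 (0.60 log units; beyond the scatter) and so provides the first step here that can be read at a single place. The step is modest but lies beyond the scatter, which shows that even in these weak inhibitors, the activity responds to the addition of one carbon at this position of the six-membered aromatic ring. Nothing at hand accounts for this response, and its origin remains unknown.

The compounds shown leave open whether an ethyl, a methoxy or an amine at this same place would extend the step, hold it or reverse it, and so whether anything about the step is particular to methyl. They also leave open whether a methyl on another carbon of the ring would give a similar change, and whether the same step would appear on the core of compound 1.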